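This account rests on a few compounds, and the source may have more. Where it says the series, first, only, none or still open, it means among the compounds named here.

Working notes on the series. Compound 1 `C=CC(=O)Nc1cccc(Nc2ncnc(Nc3ccc(C(=O)Nc4ccccn4)cc3)n2)c1` carries the shared core with an acrylamide on one aryl amine and a second aryl amine bearing a (pyridin-2-yl)carbamoyl group; in a functional assay on Ramos cells (Homo sapiens) for antiproliferative activity, read by CCK-8 assay, with a stated time of 24 h (on this read-out higher numbers stand for weaker inhibition and lower numbers for stronger inhibition), compound 1 stands as "not determined" (no result reported), so it cannot be placed on the scale. Among the measured compounds shown here, the two measured members give the only bearings. Compound 2 `CC#CC(=O)Nc1cccc(Nc2ncnc(Nc3ccc(C(=O)N4CCCCC4)cc3)n2)c1`, with a butynamide and a piperidine amide, gives in this assay 24400 nM. Compound 3 `C=CC(=O)Nc1cccc(Nc2nc(Cl)nc(Nc3ccc(Oc4ccccc4)cc3)n2)c1`, with an acrylamide, a chloro substituent on the core and a phenoxy group, gives in this assay 12300 nM. The two values sit within the usual scatter of each other, so both point to weak antiproliferative activity on these cells and nothing more. Compound 4 `C=CC(=O)Nc1cccc(Nc2ncnc(Nc3ccc(OCCOC)cc3)n2)c1` differs from compound 1 in one place: 2-methoxyethoxy in place of (pyridin-2-yl)carbamoyl on an aromatic carbon. For the measured compounds named here, no measured pair shows this change, so no step size can be drawn from the data; the expectation rests only on compounds 2 and 3 lying in the weak range, and no shift beyond the scatter is assumed for compound 4. Compound 4 is expected to give in this assay about 20000 nM, within 5000 nM to 80000 nM.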

Compound 4, half-maximal inhibitory concentration: 181000 nM
Compound 4: the middle estimate sits 9.1-fold (0.96 log units) below what was measured, and the stated range ends below it.
By their numbers in this assay, from the lowest: compounds 3 and 2 (each within the scatter of the next); then compound 4.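

Compound 4 at 181000 nM forms no readable step with compound 1, which has no single number on this scale. The compounds shown leave open how 2-methoxyethoxy and (pyridin-2-yl)carbamoyl compare on this read-out. No evidence bearing on the result is available.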